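Swapping the Aryl Substituent in a Sulfonamide Series

The compounds below may be only part of what the source reports. "The series", "measured", "known", "first", "only" and "open" are said of these compounds alone.

The compounds measured so far are:
compound 1 `CC1CCN(C2CCN(S(=O)(=O)c3cccnc3Cl)CC2)CC1`, a functional assay on DLD-1 cells (Homo sapiens) for antiproliferative activity, read by CellTiter-Glo, with a stated time of 72 h; a higher number here means a weaker inhibitor, a lower number a stronger inhibitor > 5000 nM;
compound 2 `COc1ccccc1-c1ccc(S(=O)(=O)N2CCC(N3CCC(C)CC3)CC2)cc1`, 26 nM;
compound 3 `COc1ccc(Br)cc1S(=O)(=O)N1CCC(N2CCC(C)CC2)CC1`, 2 nM.

For compound 1 the value is a limit of the assay and not a number. Among the two numbers given, compound 2 has the highest value in this assay; its nearest neighbour is compound 3, whose value is lower by a gap beyond the usual scatter. Among the measured compounds shown here, no step between two measured compounds that differ in one place is available, so the size of a single change cannot be read off directly.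

Compound 4 `CC1CCN(C2CCN(S(=O)(=O)c3ccc(-c4ccc(Cl)cc4)cc3)CC2)CC1` is not yet measured. It differs from compound 2 in one place: 4-chlorophenyl in place of 2-methoxyphenyl on an aromatic carbon. A four-chlorophenyl group replaces the two-methoxyphenyl group on the aromatic carbon, para to a large group; the ring that enters carries no hydrogen-bond acceptor, while the one that leaves carried one. For the measured compounds named here, with no measured step of this kind to lean on, the step from compound 2 to compound 4 is expected to be small, probably within the scatter, in either direction: a 1.2-fold higher number from compound 2 to compound 4 (0.06 log units; within the scatter). Compound 4 is therefore estimated at 30 nM, with a range from 8 nM to 120 nM.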

Compound 4, half-maximal inhibitory concentration: 105 nM
Compound 4: the middle estimate sits 3.5-fold (0.54 log units) below what was measured; the range from low to high includes it.
By their numbers in this assay, from the lowest: compound 3; then compound 2; then compound 4. At a limit, above all of these: compound 1.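

In this assay the aryl group on this aromatic carbon is not freely interchangeable: 4-chlorophenyl in place of 2-methoxyphenyl gives a 4.0-fold higher number from compound 2 to compound 4 (0.61 log units; beyond the scatter) and this step lies beyond the scatter. It is the only change shown so far that touches a single place, so it gives the only direct sign that the ring at this position, para to a large group, can move the number on its own while the rest of the molecule stays the same. Nothing measured here accounts for the size or direction of this step.

This one swap alters several features at once, namely the kind of substituent, where it sits on the entering ring, and the hydrogen-bond acceptor count, so the compounds shown cannot separate the contribution of the chlorine from that of the lost methoxy group. They also leave open how a plain phenyl ring, or a phenyl ring carrying an amine or a carboxylic acid, would behave at this position.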